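Swapping a Fused Ring for a Pyridinylmethoxy Arm

The compounds below may be only part of what the source reports. "The series", "measured", "known", "first", "only" and "open" are said of these compounds alone.

Three measured compounds share one core and differ only in the group attached to one aromatic carbon. Compound 1 `Cc1cccc(C[C@H](O)/C=C/[C@H]2CCC(=O)N2CCSCCCC(=O)O)c1` carries a methyl there, compound 2 `O=C(O)CCCSCCN1C(=O)CC[C@@H]1/C=C/[C@@H](O)Cc1cccc(-c2nc3ccccc3s2)c1` a 1,3-benzothiazol-2-yl, and compound 3 `O=C(O)CCCSCCN1C(=O)CC[C@@H]1/C=C/[C@@H](O)Cc1cccc(-c2cc3ccccc3o2)c1` a 1-benzofuran-2-yl. In a functional assay on CHO cells for agonist activity at prostaglandin E2 receptor EP4 subtype (Rattus norvegicus), read by cAMP accumulation and immunoassay, with a stated time of 10 min (a higher number here means that more compound is needed for the effect, a lower number that less compound is needed), compound 1 gives 5.7 nM, compound 2 gives 3.2 nM, and compound 3 gives 7 nM. Compound 3 therefore has the highest of the three numbers, yet one step, a 1.2-fold higher number from compound 1 to compound 3 (0.09 log units; within the scatter), lies within the scatter, while the other, a 2.2-fold higher number from compound 2 to compound 3 (0.34 log units; beyond the scatter), is modest but beyond it.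

Compound 4 `O=C(O)CCCSCCN1C(=O)CC[C@@H]1/C=C/[C@@H](O)Cc1cccc(OCc2ccncc2)c1` is compound 3 with one further change: (pyridin-4-yl)methoxy in place of 1-benzofuran-2-yl on an aromatic carbon. Among the measured compounds shown here, no measured step replaces this fused ring with a flexible ether arm, so the comparison is indirect. What the measured steps do show is that this position accepts very different groups with little effect on the numbers: a 1.8-fold lower number from compound 1 to compound 2 (0.25 log units; within the scatter) and a 1.2-fold higher number from compound 1 to compound 3 (0.09 log units; within the scatter) both stayed within the scatter. A step of similar size is therefore expected here, with no clear direction beyond the scatter. Compound 4 is estimated at 9 nM in this assay, with a range from 3 nM to 27 nM. This estimate amounts to an expected 1.3-fold higher number from compound 3 to compound 4 (0.11 log units; within the scatter).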

Compound 4, half-maximal effective concentration: 46 nM
For compound 4 the middle estimate is 5.1-fold (0.71 log units) below the measured one; the measured number lies above the stated range.
By their numbers in this assay, from the lowest: compounds 2, 1 and 3 (each within the scatter of the next, the first and the last beyond it); then compound 4.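

In this assay, methyl, 1,3-benzothiazol-2-yl and 1-benzofuran-2-yl had kept the numbers within a narrow span, but (pyridin-4-yl)methoxy breaks out of it with a 6.6-fold higher number from compound 3 to compound 4 (0.82 log units; beyond the scatter) and an 8.1-fold higher number from compound 1 to compound 4 (0.91 log units; beyond the scatter) and, largest of the three, a 14-fold higher number from compound 2 to compound 4 (1.16 log units; beyond the scatter) in this small set. This position on an aromatic carbon, meta to a large group, therefore does not accept every group equally, and heavy-atom count does not predict the outcome: the entering arm has 8 heavy atoms and the leaving 1-benzofuran-2-yl has 9, while the much smaller methyl of compound 1 goes against any simple link between size and the number. Nothing shown here explains why the number rises with this arm.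

The change replaces the whole group at once, so the compounds shown cannot separate the effect of the ether oxygen and its one-carbon link from that of the ring nitrogen. As far as these compounds go, a plain benzyloxy arm or a pyridin-4-yl attached directly to the aromatic carbon would pull these parts apart, and how an amine or a carboxylic acid would fare at this position also remains open.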